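Replacing Dimethylamino with Methylpiperazinyl on the Chain

A few compounds are considered here, and "the series" means these few. Any claim that something is new, unique, unknown or untested is made for them only; others in the source may bear on it.

Going by the values given here, compound 1 `CN(C)CCCn1cc(C2=C(Nc3ccccc3)C(=O)NC2=O)c2ccccc21` is one of two compounds measured so far in an assay on isolated protein for inhibition of protein kinase C epsilon type (Homo sapiens) (on this read-out higher numbers stand for weaker inhibition and lower numbers for stronger inhibition), where compound 1 gives 3460 nM. Its companion, compound 2 `Cc1cccc(NC2=C(c3cn(CCCN(C)C)c4ccccc34)C(=O)NC2=O)c1`, carries a methyl in place of hydrogen on an aromatic carbon, and in this assay compound 2 gives 3460 nM. The single measured step, no change at the digits printed from compound 1 to compound 2 (within the scatter), lies within the scatter, so compound 1 stands level with compound 2 at the digits shown and has no measured neighbour that moves it either way.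

Compound 3 `CN1CCN(CCCn2cc(C3=C(Nc4ccccc4)C(=O)NC3=O)c3ccccc32)CC1` has not yet been measured. It differs from compound 1 in that (4-methylpiperazin-1-yl in place of dimethylamino on a saturated chain carbon, three bonds along the chain from an aromatic nitrogen). Among the compounds with values here, the one measured step concerns a methyl on an aromatic carbon rather than the saturated chain, so it does not speak to this change, and nothing else among the measured compounds bears on the chain substituent. With no precedent in either direction, the expected step of a 1.0-fold higher number from compound 1 to compound 3 (0.00 log units; within the scatter) is none beyond the scatter, though the uncertainty is wide. Compound 3 is therefore estimated at 3500 nM, with a range from 1200 nM to 10000 nM.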

Compound 3, half-maximal inhibitory concentration: > 10000 nM
Compound 3: a limit, no number; the forecaster's own chance of this, stated with the estimate: 5%; at least 2.8-fold (0.45 log units) between middle value and limit.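

On the 3-(dimethylamino)propyl chain, 4-methylpiperazin-1-yl in place of dimethylamino gives an at least 2.8-fold higher number from compound 1 to compound 3 (0.46 log units; beyond the scatter), whereas the methyl on an aromatic carbon gave no change at the digits printed from compound 1 to compound 2 (within the scatter). The saturated chain position therefore responds to a change in this assay in a way the earlier pair could not show, and of these two chain ends, dimethylamino gives the stronger inhibition. The value of compound 3 is a limit and not a number, so the full size of the step remains unfixed: the limit of > 10000 nM in this assay, at which 1 of the 3 values shown sits.

The compounds shown leave open whether the ring as such or the methyl-bearing ring nitrogen of 4-methylpiperazin-1-yl accounts for the difference, a question that a piperidine, a morpholine or an unsubstituted piperazine on the same chain would help to separate. They also leave open whether a smaller primary amine or a shorter or longer chain would move the number in either direction, and whether the methyl on the aromatic carbon would stay without effect alongside a different chain end.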